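Indole for benzothiophene in a melanocortin receptor binding series

The source may report more compounds than this note shows. Statements on the series, on what has been measured and on what is new or still open speak of the compounds shown alone.

Three compounds share one core and differ only in the aromatic group at the end of a short chain attached to the amide. Compound 1 `Cc1cccc(CCC(=O)N2CCN(c3ccc(C(F)(F)F)cc3[C@@H](N)CC(C)C)CC2)c1` carries 3-methylphenyl there and in an assay on HEK293 cells for displacement of a labelled ligand from Melanocortin receptor 4 (Homo sapiens) (a lower number here means a stronger inhibitor, a higher number a weaker inhibitor), compound 1 gives 2100 nM. Compound 2 `CC(C)C[C@H](N)c1cc(C(F)(F)F)ccc1N1CCN(C(=O)CCc2cccs2)CC1` carries thiophen-2-yl and in this assay compound 2 gives 4600 nM, a change of a 2.2-fold higher number from compound 1 to compound 2 (0.34 log units; beyond the scatter). Compound 3 `CC(C)C[C@H](N)c1cc(C(F)(F)F)ccc1N1CCN(C(=O)CCc2csc3ccccc23)CC1` carries 1-benzothiophen-3-yl and in this assay compound 3 gives 2300 nM, the second highest of the three numbers; its nearest neighbour is compound 1 at a 1.1-fold higher number from compound 1 to compound 3 (0.04 log units; within the scatter), and from compound 2 the step is a 2.0-fold lower number from compound 2 to compound 3 (0.30 log units; within the scatter).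

Compound 4 `CC(C)C[C@H](N)c1cc(C(F)(F)F)ccc1N1CCN(C(=O)CCc2c[nH]c3ccccc23)CC1` is the next step: 1H-indol-3-yl in place of 1-benzothiophen-3-yl on a saturated chain carbon, two bonds along the chain from a carbonyl carbon. Among the compounds with values here, none of the measured steps exchanges a sulfur-containing ring for a nitrogen-containing one, so only the general picture helps: the two measured changes of the aromatic group moved the number within or just beyond the scatter. The step of no change at the digits printed from compound 3 to compound 4 (within the scatter) is therefore expected to stay within the scatter. For compound 4 the estimate in this assay is 2300 nM, with a range from 700 nM to 7500 nM.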

Compound 4, inhibition constant: 640 nM
Beside the measured number, compound 4's estimate is 3.6-fold (0.56 log units) above it; the measured number lies below the stated range.
By their numbers in this assay, from the lowest: compound 4; then compounds 1, 3 and 2 (each within the scatter of the next, the first and the last beyond it).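

Exchanging only the ring sulfur of 1-benzothiophen-3-yl for the ring nitrogen of 1H-indol-3-yl gives a 3.6-fold lower number from compound 3 to compound 4 (0.56 log units; beyond the scatter) in this assay, even though the two groups have the same ring sizes and heavy-atom count, so the identity of that single ring atom matters at this position. Within the data shown here, compound 4 is also the first compound here to separate from all the others and is the strongest inhibitor of the four, with a 3.3-fold lower number from compound 1 to compound 4 (0.52 log units; beyond the scatter) and a 7.2-fold lower number from compound 2 to compound 4 (0.86 log units; beyond the scatter). Nothing available explains why this exchange has such an effect.

On these data alone, it remains open whether the hydrogen on the indole nitrogen is needed, which 1-methyl-1H-indol-3-yl at the same position would test. As far as these compounds go, it is also open whether the gain would survive a longer chain between the carbonyl and the indole.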